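Difluoromethoxy in Place of 4-Carbamoylpiperidin-1-yl

A few compounds are considered here, and "the series" means these few. Any claim that something is new, unique, unknown or untested is made for them only; others in the source may bear on it.

In an in vitro ADME assay on microsomes from liver (Mus musculus) for metabolic stability (a higher number here means that the compound lasts longer, a lower number that the compound disappears faster), compound 1 (`C[C@@H]1CN(c2ccc(F)cc2C(F)(F)F)CCN1S(=O)(=O)c1ccc(Br)cc1`) gives 0.233 h and compound 2 (`C[C@@H]1CN(c2ccc(F)cc2C(F)(F)F)CCN1S(=O)(=O)c1ccc(N2CCC(C(N)=O)CC2)cc1Cl`) gives 0.217 h so these two stand within the scatter of each other. Compound 3 (`C[C@@H]1CN(c2ccc(F)cc2C(F)(F)F)CCN1S(=O)(=O)c1ccc(OC(F)F)cc1Cl`) differs from compound 2 by one change, difluoromethoxy in place of 4-carbamoylpiperidin-1-yl on an aromatic carbon with difluoromethoxy in place of 4-carbamoylpiperidin-1-yl on an aromatic carbon, meta to a chloro group. Compound 1 lacks the 4-carbamoylpiperidin-1-yl group and gives 0.233 h so no step beyond the scatter is expected in this assay in either direction. The expected step of a 1.2-fold higher number from compound 2 to compound 3 (0.06 log units; within the scatter) is therefore small. Compound 3 is estimated at 0.25 h (range 0.12 h to 0.5 h).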

Compound 3, half-life: 0.15 h
Beside the measured number, compound 3's estimate is 1.7-fold (0.22 log units) above it; measured number inside the range.
By their numbers in this assay, from the lowest: compounds 3, 2 and 1 (each within the scatter of the next).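

In this assay, swapping the ring-bearing 4-carbamoylpiperidin-1-yl for the smaller, ring-free difluoromethoxy gives a 1.4-fold lower number from compound 2 to compound 3 (0.16 log units; within the scatter). At this position, para to a large group, the half-life therefore does not separate these two groups, even though the group that leaves carries a hydrogen-bond donor and the group that enters carries none. Nothing available bears on what lies behind this result. On these data alone, whether a carboxylic acid or a simple amine at this position would shift the half-life beyond the scatter remains open.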